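The source may report more compounds than this note shows. Statements on the series, on what has been measured and on what is new or still open speak of the compounds shown alone.

Measured so far in a functional assay on MCF7 cells (Homo sapiens) for antiproliferative activity, read by MTT assay, with a stated time of 72 h; on this read-out higher numbers stand for weaker inhibition and lower numbers for stronger inhibition
compound 1 `CCC/C=C/C(=O)Nc1cccc(Oc2nc(Nc3ccn(C)n3)nc3c2CSCC3)c1` gives 22600 nM
compound 2 `CCC/C=C/C(=O)Nc1cccc(Oc2nc(Nc3cccc(OC)c3)nc3c2CSCC3)c1` gives 32000 nM
compound 3 `C/C=C/C(=O)Nc1cccc(Oc2nc(Nc3ccc(OC)nc3)nc3c2CSCC3)c1` gives 21100 nM

All three values lie within the usual scatter of one another, so compound 3 at 21100 nM stands level with the other two. Compound 4 `CCC/C=C/C(=O)Nc1cccc(Oc2nc(Nc3ccc(OC)nc3)nc3c2CSCC3)c1` differs from compound 3 only in its chain. The change is ethyl in place of hydrogen on a saturated chain carbon bound to a double-bonded chain carbon and it turns prop-1-en-1-yl into pent-1-en-1-yl. Among the measured compounds shown here, no measured step isolates this change. For the measured compounds named here, the only measured step swaps the group on the nitrogen and shows a 1.4-fold higher number from compound 1 to compound 2 (0.15 log units; within the scatter) in a different place. Compound 1 already carries pent-1-en-1-yl and gives 22600 nM within the scatter of compound 3, so no step beyond the scatter is expected. The estimated step is a 1.1-fold higher number from compound 3 to compound 4 (0.06 log units; within the scatter) in this assay on this reasoning. For compound 4 the estimated value is 24000 nM with an expected range from 13000 nM to 42000 nM on this estimate.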

Compound 4, half-maximal inhibitory concentration: 26800 nM
Compound 4: the middle estimate sits 1.1-fold (0.05 log units) below what was measured; low and high end bracket the measured number.
By their numbers in this assay, from the lowest: compounds 3, 1, 4 and 2 (each within the scatter of the next).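

In this assay, among the compounds shown here, pent-1-en-1-yl in place of prop-1-en-1-yl, which no earlier pair isolated, gives a step within the scatter (a 1.3-fold higher number from compound 3 to compound 4 (0.10 log units; within the scatter)). With pent-1-en-1-yl held fixed, 6-methoxypyridin-3-yl on the nitrogen also stays within the scatter of 3-methoxyphenyl (a 1.2-fold lower number from compound 2 to compound 4 (0.08 log units; within the scatter)) and of 1-methyl-1H-pyrazol-3-yl (a 1.2-fold higher number from compound 1 to compound 4 (0.07 log units; within the scatter)). Nothing measured here offers an explanation for these results. From the compounds shown here alone, whether a longer chain than pent-1-en-1-yl, or an amine or a carboxylic acid in its place, would move the number beyond the scatter remains open.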